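Swapping a Chain-Bearing Group for a Methoxyphenyl Ring

The source may hold more compounds than are shown below. What is called first, only, known or untested is meant among the compounds shown, and "the series" means these compounds.

The compounds here share one core and are tested in a functional assay on WI-38 VA13 cells (Homo sapiens) for cytotoxicity; on this read-out higher numbers stand for an effect only at larger amounts of compound and lower numbers for an effect already at smaller amounts. Compound 1 `CCCC(=O)Nc1nc2ccc(NC(=O)c3c(Cl)cccc3Cl)cc2s1` gives 0.01 ug/mL. Within the data shown here, compound 2 `CCCCCCNC(=O)Nc1nc2ccc(NC(=O)c3c(Cl)cccc3Cl)cc2s1` gives 0.29 ug/mL, the higher of the two numbers measured so far; the step of a 29-fold higher number from compound 1 to compound 2 (1.46 log units; beyond the scatter) is large and lies beyond the usual scatter of such measurements. Compound 3 `COc1cccc(Nc2nc3ccc(NC(=O)c4c(Cl)cccc4Cl)cc3s2)c1` has not yet been measured. It differs from compound 2 in one place: 3-methoxyphenyl in place of hexylcarbamoyl on a nitrogen on an aromatic ring. Among the measured compounds shown here, no measured step describes this kind of exchange, a chain-bearing group on a ring nitrogen giving way to an aromatic ring. For the measured compounds named here, the single step available, from compound 1 to compound 2, concerns a change on the carbonyl carbon and shows only that this part of the molecule can move the read-out by a large amount. For compound 3 a number somewhere between those of compound 2 and compound 1 is therefore expected, a step of a 2.9-fold lower number from compound 2 to compound 3 (0.46 log units; beyond the scatter) toward lower numbers, with wide uncertainty. The estimate for compound 3 is 0.1 ug/mL, expected to fall between 0.01 ug/mL and 1 ug/mL.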

Compound 3, half-maximal effective concentration: > 7.2 ug/mL
Compound 3: only a limit was reported (the forecaster's own chance of this, stated with the estimate: 5%); middle value at least 72-fold (1.85 log units) away from the limit.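

Compound 3 is reported only as a limit, not as a number: the limit of > 7.2 ug/mL in this assay, at which 1 of the 3 values shown sits. In this assay, putting 3-methoxyphenyl in place of hexylcarbamoyl on this nitrogen gives an at least 24-fold higher number from compound 2 to compound 3 (1.39 log units; beyond the scatter), so the large effect of changing this group is not confined to exchanges on the carbonyl carbon, and this time the shift is again toward effects only at larger amounts. Among these compounds, putting the same ring in place of propylcarbonyl gives an at least 720-fold higher number from compound 1 to compound 3 (2.85 log units; beyond the scatter), and since compound 1 and compound 2 both keep a carbonyl on this nitrogen, compound 3 shows that the one exchange removing that carbonyl and adding an aromatic ring gives the highest reading of the three.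

The change does two things at once, losing the carbonyl and gaining the ring, so these compounds cannot tell which of the two matters; a benzoyl group, which keeps the carbonyl and carries a ring, would help separate them. Going by these compounds, whether the methoxy group itself plays any part also stays open, and a plain phenyl group on the same nitrogen would bear on that question.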